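Imidazolyl for Fluoro on a Chalcone Scaffold

This account rests on a few compounds, and the source may have more. Where it says the series, first, only, none or still open, it means among the compounds named here.

Compound 1, `COc1cc(OC)c(OC)cc1/C=C/C(=O)c1ccc(OC)c2c1OC(C)(C)C=C2`, gives in a functional assay on HCT-116 cells (Homo sapiens) for antiproliferative activity, read by MTT assay, with a stated time of 24 h (on this read-out higher numbers stand for weaker inhibition and lower numbers for stronger inhibition), a limit of > 10000 nM.
Compound 2, `COc1ccc(C(=O)/C=C/c2ccc(F)cc2)c2c1C=CC(C)(C)O2`, gives in this assay a limit of > 10000 nM.

Compound 2 thus sits at the limit of the assay and not at a number, and the limit of > 10000 nM in this assay, at which 2 of the 2 values shown sit, describes where both shown values stand. Compound 3, `COc1ccc(C(=O)/C=C/c2ccc(-n3ccnc3)cc2)c2c1C=CC(C)(C)O2`, differs from compound 2 by 1H-imidazol-1-yl in place of fluoro on an aromatic carbon. Among the measured compounds shown here, with no measured step available, the account expects a change from compound 2 to compound 3 of a step that the limit leaves unreadable from compound 2 to compound 3, that is, none beyond the scatter, since nothing measured points otherwise. For compound 3 the expected value in this assay is 15000 nM, with a range from 3000 nM to 60000 nM.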

Compound 3, half-maximal inhibitory concentration: > 10000 nM
Compound 3: only a limit was reported; the forecaster's own chance of this, stated with the estimate: 65%; the middle value does not contradict the limit.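

Among the compounds shown here, compound 3, like compound 2, gives only a limit, so no step between compound 2 and compound 3 can be read: the limit of > 10000 nM in this assay, at which 3 of the 3 values shown sit. The compounds shown leave open whether 1H-imidazol-1-yl in place of fluoro changes the activity at all.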